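The source may report more compounds than this note shows. Statements on the series, on what has been measured and on what is new or still open speak of the compounds shown alone.

Measured in a functional assay on HeLa cells (Homo sapiens) for inhibition, read by sulforhodamine B assay; on this read-out lower numbers stand for stronger inhibition and higher numbers for weaker inhibition:
- Compound 1 `O=C1C=C(NCc2ccccc2)C(=O)c2c1nc1n2[C@H]2OC[C@@H](O)[C@H]2OC1`: > 8000 nM (a limit)
- Compound 2 `O=C1C=C(Nc2ccccc2F)C(=O)c2c1nc1n2[C@H]2OC[C@@H](O)[C@H]2OC1`: 5120 nM
- Compound 3 `CCOc1ccc(NC2=CC(=O)c3nc4n(c3C2=O)[C@H]2OC[C@@H](O)[C@H]2OC4)cc1`: 3110 nM

Among the measured compounds shown here, compound 3 and compound 2 are the only two with true numbers, and these lie within the scatter of each other, with a 1.6-fold lower number from compound 2 to compound 3 (0.22 log units; within the scatter). Compound 1 gave only a limit. Against that limit, the change is an at least 2.5-fold lower number from compound 1 to compound 3 (0.41 log units; beyond the scatter).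

Compound 4 `Cc1ccc(NC2=CC(=O)c3nc4n(c3C2=O)[C@H]2OC[C@@H](O)[C@H]2OC4)cc1` keeps the rest of compound 3 and differs in one place: methyl in place of ethoxy on an aromatic carbon. This puts methyl in place of ethoxy on an aromatic carbon, para to a large group. For the measured compounds named here, no measured step makes this exact exchange. Going by the values given here, the closest precedent is the swap between two substituted phenyl groups on the amine nitrogen, a 1.6-fold lower number from compound 2 to compound 3 (0.22 log units; within the scatter), so no step beyond the scatter is expected in this assay. The expected change is a 1.2-fold higher number from compound 3 to compound 4 (0.09 log units; within the scatter). For compound 4 the estimated value is 3800 nM. The expected range for compound 4 runs from 1800 nM to 8000 nM.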

Compound 4, half-maximal inhibitory concentration: 3860 nM
Beside the measured number, compound 4's estimate is 1.0-fold (0.01 log units) below it, and the stated range covers the measured number.
By their numbers in this assay, from the lowest: compounds 3, 4 and 2 (each within the scatter of the next). At a limit, above all of these: compound 1.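

In this assay, ethoxy on an aromatic carbon, para to a large group, can be exchanged for methyl, going from 3 heavy atoms and 1 hydrogen-bond acceptor to 1 heavy atom and no acceptor, with a 1.2-fold higher number from compound 3 to compound 4 (0.09 log units; within the scatter). Among the compounds shown here, compounds 1 to 3 differed only in the whole group on the amine nitrogen, so this is the first sign that the ether oxygen is not needed to keep the number, and the 4-methylphenyl group also stays close to the 2-fluorophenyl group, with a 1.3-fold lower number from compound 2 to compound 4 (0.12 log units; within the scatter). Compound 1 remains a limit of the assay, and against it the change is an at least 2.0-fold lower number from compound 1 to compound 4 (0.31 log units; beyond the scatter): the limit of > 8000 nM in this assay, at which 1 of the 4 values shown sits.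

On these data alone, whether a hydroxyl, an amine, a carboxylic acid or a longer chain such as propoxy at this place would leave the number unchanged stays open. As far as these compounds go, whether the same holds outside this assay also stays open.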